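Reversing the Amide Link of Compound 1

This account rests on a few compounds, and the source may have more. Where it says the series, first, only, none or still open, it means among the compounds named here.

Among the measured compounds shown here, compound 1 `CCNc1nc(NCc2ccc(NC(=O)c3ccc(F)cc3)cc2)c2ccccc2n1` gives 1400 nM in a functional assay on HCT-116 cells (Homo sapiens) for inhibition, read by luminescence and resazurin assay, with a stated time of 3 days (on this read-out higher numbers stand for weaker inhibition and lower numbers for stronger inhibition), the lowest of the two numbers measured so far. Compound 2 `CN1CCN(c2nc(NCc3ccc(NC(=O)c4ccc(F)cc4)cc3)c3ccccc3n2)CC1` gives 1800 nM in this assay, and the step of a 1.3-fold higher number from compound 1 to compound 2 (0.11 log units; within the scatter) changes a different part of the molecule. Compound 3 `CCNc1nc(NCc2ccc(C(=O)Nc3ccc(F)cc3)cc2)c2ccccc2n1` differs from compound 1 by (4-fluorophenyl)carbamoyl in place of ((4-fluorophenyl)carbonyl)amino on an aromatic carbon. For the measured compounds named here, no measured step bears on this change, so the estimate rests on compound 1 alone and carries a wide range. For compound 3 the step of no change at the digits printed from compound 1 to compound 3 (within the scatter) is expected to stay within the scatter. Compound 3 is estimated at 1400 nM, between 350 nM and 5600 nM.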

Compound 3, half-maximal inhibitory concentration: 1900 nM
Compound 3: the middle estimate sits 1.4-fold (0.13 log units) below what was measured; the measured number falls inside the stated range.
By their numbers in this assay, from the lowest: compounds 1, 2 and 3 (each within the scatter of the next).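

Among the compounds shown here, replacing ((4-fluorophenyl)carbonyl)amino with (4-fluorophenyl)carbamoyl joins the same atoms differently and gives a 1.4-fold higher number from compound 1 to compound 3 (0.13 log units; within the scatter), the first measured step at this position. Reversing the amide link here therefore has no effect that can be told apart from the scatter. No evidence is available to explain this result.

The compounds shown leave open whether a different link, such as a sulfonamide or a plain amine, would be tolerated here. They also leave open what happens when chlorine or a methoxy group replaces the fluorine.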